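Swapping an Amide Substituent in a Cytotoxicity Series

A few compounds are considered here, and "the series" means these few. Any claim that something is new, unique, unknown or untested is made for them only; others in the source may bear on it.

Compound 1 `C=CC1=C(C(=O)NCCC)C(c2ccc(F)cc2)OC1` gives > 100000 nM in a functional assay on A549 cells (Homo sapiens) for cytotoxicity, read by MTT assay, with a stated time of 24 h (a lower number here means a stronger inhibitor, a higher number a weaker inhibitor), which is a limit of the assay.
Compound 2 `C=CC1=C(C(=O)NCc2ccc(C)cc2)C(c2ccc(F)cc2)OC1` gives > 100000 nM in this assay, again a limit.
Compound 3 `C=CC1=C(C(=O)Nc2ccccc2OC)C(c2ccc(F)cc2)OC1` gives > 100000 nM in this assay, also a limit.

Compound 3 therefore stands at the top of the measured range, together with both companions: the limit of > 100000 nM in this assay, at which 3 of the 3 values shown sit. The steps among them, a step that the two limits leave unreadable from compound 1 to compound 2, a step that the two limits leave unreadable from compound 1 to compound 3 and a step that the two limits leave unreadable from compound 2 to compound 3, cannot be sized, so they give no direction. Compound 4 `C=CC1=C(C(=O)NCc2ccccc2F)C(c2ccc(F)cc2)OC1` carries 2-fluorobenzyl in place of 2-methoxyphenyl on an amide-type nitrogen. With no readable step among the three measured compounds, there is no basis to expect anything but another limit. Compound 4 is estimated at 150000 nM, within 40000 nM to 600000 nM. The expected step that the limit leaves unreadable from compound 3 to compound 4 is none beyond the scatter.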

Compound 4, half-maximal inhibitory concentration: > 100000 nM
Compound 4 ended at the assay's limit (the forecaster's own chance of this, stated with the estimate: 85%); the middle value is on the limit's open side.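

In this assay, among the compounds shown here, compound 4 gives > 100000 nM as a limit, like compound 1, compound 2 and compound 3, and no step among them can be read. Going by these compounds, whether any amide substituent on the shared core gives a value short of that limit stays open.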